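Removing the methyl from the chloro analogue

The source may report more compounds than this note shows. Statements on the series, on what has been measured and on what is new or still open speak of the compounds shown alone.

Compound 3 `CC(C)n1c(/C=C2/C(=O)Nc3ccc(Cl)cc32)nc2ccccc21` gives 32800 nM in a functional assay on HGC cells (Homo sapiens) for cytotoxicity, read by MTT assay, with a stated time of 48 h; on this read-out lower numbers stand for stronger inhibition and higher numbers for weaker inhibition. Of the two numbers in this assay it is the lower, and compound 1 `CC(C)n1c(/C=C2/C(=O)Nc3ccccc32)nc2ccccc21` stands nearest at 33500 nM; the step of a 1.0-fold lower number from compound 1 to compound 3 (0.01 log units; within the scatter) lies within the scatter. Compound 2 `CCn1c(/C=C2/C(=O)Nc3ccccc32)nc2ccccc21` reaches only the limit of > 50000 nM in this assay, not a number. Compound 4 `CCn1c(/C=C2/C(=O)Nc3ccc(Cl)cc32)nc2ccccc21` differs from compound 3 by hydrogen in place of methyl on a saturated chain carbon bound to an aromatic nitrogen and a saturated chain carbon. The same change has been seen once, as an at least 1.4-fold higher number from compound 1 to compound 2 (0.17 log units; that floor lies within the scatter), where the result was a limit, (the limit of > 50000 nM in this assay, at which 1 of the 3 values shown sits), so the full size of that step is not known. A rise of similar or larger size is therefore expected in this assay for compound 4, with a limit likely. Compound 4 is estimated at 55000 nM (range 30000 nM to 120000 nM), an expected step of a 1.7-fold higher number from compound 3 to compound 4 (0.22 log units; within the scatter).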

Compound 4, half-maximal inhibitory concentration: > 50000 nM
Compound 4: a limit, no number; the forecaster's own chance of this, stated with the estimate: 60%; the middle value lies beyond the limit too.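

Isopropyl to ethyl has now been read on a second core, the chloro one, with an at least 1.5-fold higher number from compound 3 to compound 4 (0.18 log units; that floor lies within the scatter) in this assay. Both ethyl compounds end at a limit, so neither step has a full size: the same change on two cores in this assay, an at least 1.4-fold higher number (0.17 log units; that floor lies within the scatter) from compound 1 to compound 2 and an at least 1.5-fold higher number (0.18 log units; that floor lies within the scatter) from compound 3 to compound 4; the limit leaves it open whether they differ. Chloro does not give compound 4 a readable number, and the series now sits at that limit more often: the limit of > 50000 nM in this assay, at which 2 of the 4 values shown sit.

The chloro step from compound 2 to compound 4 cannot be read, as both values are limits. From the compounds shown here alone, how a longer chain or an aminoethyl group would read in place of isopropyl remains open.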